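The compounds below may be only part of what the source reports. "The series", "measured", "known", "first", "only" and "open" are said of these compounds alone.

Measured compounds:
- compound 1 `CN1CCN(c2ccc(NC(=N)c3cc4cnn(C)c4cn3)cc2)CC1`: 24000 nM
- compound 2 `COc1ccc(Cn2ncc3cc(C(=N)Nc4ccc(N5CCN(C)CC5)cc4)ncc32)cc1`: 5300 nM
- compound 3 `CN1CCN(c2ccc(NC(=N)c3cc4c(-c5ccccc5)nn(C)c4cn3)cc2)CC1`: 1400 nM

All three were run in a functional assay on HT-1080 cells (Homo sapiens) for cytotoxicity, read by MTT assay, with a stated time of 72 h; a higher number here means a weaker inhibitor, a lower number a stronger inhibitor. Compound 1 is the parent of the set, and its number in this assay is the highest of the three. Two single changes to compound 1 are covered. The first, (4-methoxyphenyl in place of hydrogen on a saturated chain carbon bound to an aromatic nitrogen), gives compound 2 and a step of a 4.5-fold lower number from compound 1 to compound 2 (0.66 log units; beyond the scatter). The second, (phenyl in place of hydrogen on an aromatic carbon), gives compound 3 and a step of a 17-fold lower number from compound 1 to compound 3 (1.23 log units; beyond the scatter); compound 3 is the strongest inhibitor of the three, its steps to both others lying beyond the scatter.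

Compound 4 `COc1ccc(Cn2nc(-c3ccccc3)c3cc(C(=N)Nc4ccc(N5CCN(C)CC5)cc4)ncc32)cc1` has not been measured. Among the compounds with values here, it differs from compound 3 by 4-methoxyphenyl in place of hydrogen on a saturated chain carbon bound to an aromatic nitrogen, which is the same change as the one from compound 1 to compound 2: the groups leaving and entering and the place are identical word for word. The cores of compound 1 and compound 3 differ by phenyl in place of hydrogen on an aromatic carbon, so compound 4 carries both changes at once.

Whether the two changes add up cannot be read from these three numbers alone. The expectation for compound 4 in this assay is a step of a 3.5-fold lower number from compound 3 to compound 4 (0.54 log units; beyond the scatter), resting on the step from compound 1 to compound 2, a 4.5-fold lower number from compound 1 to compound 2 (0.66 log units; beyond the scatter), which is beyond the scatter, tempered because the starting number of compound 3, 1400 nM, is already the lowest of the set. Compound 4 is therefore estimated at 400 nM, with a likely range from 150 nM to 1200 nM.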

Compound 4, half-maximal inhibitory concentration: 1090 nM
The estimate for compound 4 lay 2.7-fold (0.44 log units) below the measured number; measured number inside the range.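

In this assay, the 4-methoxyphenyl change on a saturated chain carbon bound to an aromatic nitrogen gives a 1.3-fold lower number from compound 3 to compound 4 (0.11 log units; within the scatter) on the core of compound 3, so the gain seen on the core of compound 1 does not carry over at its full size: the same change on two cores in this assay, a 4.5-fold lower number (0.66 log units; beyond the scatter) from compound 1 to compound 2 and a 1.3-fold lower number (0.11 log units; within the scatter) from compound 3 to compound 4, 3.5-fold (0.55 log units) apart, beyond the scatter of two such steps.

Read the other way, phenyl in place of hydrogen on an aromatic carbon still gives a step beyond the scatter on the core of compound 2, a 4.9-fold lower number from compound 2 to compound 4 (0.69 log units; beyond the scatter), but this too differs from the step on the core of compound 1: the same change on two cores in this assay, a 17-fold lower number (1.23 log units; beyond the scatter) from compound 1 to compound 3 and a 4.9-fold lower number (0.69 log units; beyond the scatter) from compound 2 to compound 4, 3.5-fold (0.55 log units) apart, beyond the scatter of two such steps.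

The two changes therefore do not add up across these four compounds, though this rests on one pair of cores for each change and shows neither the reason for the shortfall nor how either change would behave on any other core.

The compounds shown leave open whether the 4-methoxyphenyl group itself matters, since a plain phenyl or a 4-chlorophenyl in its place would separate the ring from the methoxy group. They also leave open whether a longer chain, or an amine at the end of such a chain, would give a step beyond the scatter on the core of compound 3.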